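Benzyl to Cyclopropylmethyl: What to Expect for Compound 3

The source may report more compounds than this note shows. Statements on the series, on what has been measured and on what is new or still open speak of the compounds shown alone.

Going by the values given here, compound 1 `CC1=C(C(=O)OCc2ccccc2)C(c2ccoc2)NC(=O)N1` stands lowest of the two numbers measured so far in an assay on membranes from HeLa cells for displacement of a labelled ligand from adenosine receptor A3 (Homo sapiens), read by scintillation counting, with a stated time of 180 min, tested at 1 uM (on this read-out lower numbers stand for less inhibition and higher numbers for more inhibition at the one concentration tested (going by the name of the read-out)), where compound 1 gives 1%. Among the compounds with values here, its only measured neighbour is compound 2 `CC1=C(C(=O)OCc2ccccc2)C(c2ccoc2)NC(=O)N1C`, which in this assay gives 25%; the step of a number 24 percentage points higher from compound 1 to compound 2 (beyond the scatter) arises from methyl in place of hydrogen on an amide-type nitrogen in a ring. Compound 3 `CC1=C(C(=O)OCC2CC2)C(c2ccoc2)NC(=O)N1` leaves that nitrogen untouched and instead carries cyclopropyl in place of phenyl on a saturated chain carbon bound to an oxygen next to a carbonyl group; cut one bond further out, the change reads benzyl to cyclopropylmethyl. Within the data shown here, no measured step touches this part of the molecule, so the step from compound 1 to compound 2 does not bear on the change and offers no guide to its direction or size. With nothing pointing either way, the expectation for compound 3 is a step of a number 3 percentage points higher from compound 1 to compound 3 (within the scatter) that stays within the scatter of the measurement. Compound 3 is therefore estimated at 4% in this assay, with a range from 0% to 16%.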

Compound 3, a percentage reported as inhibition, at one concentration (the size of the read-out at that concentration, not a potency): 3%
Compound 3: the middle estimate sits 1 percentage points above what was measured; low and high end bracket the measured number.
By their numbers in this assay, from the lowest: compounds 1 and 3 (each within the scatter of the next); then compound 2.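

In this assay, the change of cyclopropyl in place of phenyl on a saturated chain carbon bound to an oxygen next to a carbonyl group gives a number 2 percentage points higher from compound 1 to compound 3 (within the scatter). Going by these compounds alone, this is the first reading at this position, and it shows that replacing the six-membered aromatic ring with a three-membered non-aromatic ring of carbon, with the group falling from 6 heavy atoms to 3, does not move the number beyond the scatter while the amide hydrogen stays in place. The aromatic ring of the benzyl group is therefore not required to keep this read-out where it stands, although that holds only for a pair of compounds with very little inhibition at the one concentration tested, and nothing available explains the result.

From the compounds shown here alone, what remains open is whether the same change would also leave the number unmoved on the nitrogen-methylated compound 2, which gives 25% and so offers more room to detect a loss. Also open, going by these compounds, is how this position would respond to a group of another kind, such as an amine or a longer chain.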